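One Side-Chain Exchange and Its Expected Cytotoxicity

The source may hold more compounds than are shown below. What is called first, only, known or untested is meant among the compounds shown, and "the series" means these compounds.

Compound 1 `COc1ccc(C[C@H]2COC(=O)[C@@H]2Cc2ccc(OCC(=O)Nc3ccccc3)c(OC)c2)cc1OC` was examined in an ADME assay on HeLa cells (Homo sapiens) for cytotoxicity, read by MTT assay; on this read-out lower numbers stand for stronger inhibition and higher numbers for weaker inhibition. In this assay compound 1 gives >= 600000 nM, which is a limit of the assay and not a number. Compound 1 therefore stands at the limit of >= 600000 nM in this assay, at which 2 of the 3 values shown sit. Two related compounds share its core. Compound 2 `COC(=O)[C@@H](NC(=O)CCC(=O)Oc1ccc(C[C@H]2C(=O)OC[C@@H]2Cc2ccc(OC)c(OC)c2)cc1OC)c1c[nH]c2ccccc12` also stops at a limit, giving >= 600000 nM in this assay. Among the measured compounds shown here, compound 3 `COc1ccc(C[C@H]2COC(=O)[C@@H]2Cc2ccc(OCc3cn(Cc4ccc(F)cc4)nn3)c(OC)c2)cc1OC` gives 198000 nM in this assay, the only plain number among the three.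

Compound 4 `CCN(CC)C(=O)CCC(=O)Oc1ccc(C[C@H]2C(=O)OC[C@@H]2Cc2ccc(OC)c(OC)c2)cc1OC` has not yet been measured. It differs from compound 1 in one place: a group of 11 heavy atoms (8 carbon, 1 nitrogen, 2 oxygen; no ring) in place of a group of 10 heavy atoms (8 carbon, 1 nitrogen, 1 oxygen; one six-membered aromatic ring of carbon only), on an oxygen on an aromatic ring. For the measured compounds named here, no step between measured compounds that differ in one place is known, so the expectation rests on the three values shown. Since two of them sit at the limit and compound 3 yields only a modest number, the step in this assay is expected to be none beyond the scatter. The estimated step is an at least 1.2-fold lower number from compound 1 to compound 4 (0.07 log units; that floor lies within the scatter). Compound 4 is expected to give 500000 nM in this assay, within a range from 150000 nM to 1500000 nM, most likely again as a limit.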

Compound 4, half-maximal inhibitory concentration: 213000 nM
Beside the measured number, compound 4's estimate is 2.3-fold (0.37 log units) above it; the measured number falls inside the stated range.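

In this assay, exchanging the (phenylcarbamoyl)methyl group on the oxygen on an aromatic ring for a group with no ring gives an at least 2.8-fold lower number from compound 1 to compound 4 (0.44 log units; beyond the scatter), so this position tolerates a change that moves the read-out. The entering group carries neither a ring nor a hydrogen-bond donor, so neither feature of the leaving group is required for a plain number to appear in this assay. The step is a floor and not a full size, because compound 1 stands at a limit: the limit of >= 600000 nM in this assay, at which 2 of the 4 values shown sit.

The exchange alters several things at once, so the compounds shown leave open whether the step follows the loss of the ring, the loss of the donor or the added carbonyl. From the compounds shown here alone, whether a carboxylic acid, a primary amine or a longer chain at this position would shift the number further also remains open.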